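Trimming a Benzyl Group: From Compound 1 to Compound 3

A few compounds are considered here, and "the series" means these few. Any claim that something is new, unique, unknown or untested is made for them only; others in the source may bear on it.

Measured so far:
compound 1, `CS(=O)(=O)c1ccc(C(=O)NCC(=O)N(Cc2ccccc2)Cc2ccccc2)cc1[N+](=O)[O-]`: 3600 nM
compound 2, `Cc1ccc(N2CCN(C(=O)C3CCN(C(=O)c4ccc(S(C)(=O)=O)c([N+](=O)[O-])c4)CC3)CC2)cc1`: > 60000 nM

Of the compounds shown here, two have been measured in an assay on isolated protein for inhibition of thyroid hormone receptor beta (Homo sapiens), read by fluorescence polarization; a lower number here means a stronger inhibitor, a higher number a weaker inhibitor. Compound 1 gives 3600 nM and is the only plain number among the two shown. Compound 2 gives > 60000 nM, which is a limit of this assay rather than a number (the limit of > 60000 nM in this assay, at which 1 of the 2 values shown sits). For the measured compounds named here, no step between measured compounds that differ in one place is available, so compound 2 says only that it sits at that limit, and nothing about compound 1 can be read from it.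

Compound 3 `CN(Cc1ccccc1)C(=O)CNC(=O)c1ccc(S(C)(=O)=O)c([N+](=O)[O-])c1` has not yet been measured in this assay. It differs from compound 1 in one place: hydrogen in place of phenyl on a saturated chain carbon bound to an amide-type nitrogen. The change takes a benzyl group away and leaves a methyl on the amide-type nitrogen. Going by the values given here, with no measured step to lean on, the direction is uncertain; the expected step of a 2.8-fold higher number from compound 1 to compound 3 (0.44 log units; beyond the scatter) is estimated to lean toward weaker binding, with a wide margin either way. Compound 3 is expected to give about 10000 nM, in a range from 3000 nM to 40000 nM.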

Compound 3, half-maximal inhibitory concentration: 39000 nM
Beside the measured number, compound 3's estimate is 3.9-fold (0.59 log units) below it, within the range that was stated.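

In this assay, for the compounds shown here, taking phenyl away from a saturated chain carbon bound to an amide-type nitrogen, which turns a benzyl group into a methyl, gives the first single change that can be read: an 11-fold higher number from compound 1 to compound 3 (1.03 log units; beyond the scatter). This place is therefore not indifferent to what it carries, and the benzyl group that remains on the same nitrogen in compound 3 does not make up for the one that is lost. None of the data shown gives a cause for this step, which stands only as a measured difference.

The compounds shown leave open whether phenyl is the only group that serves at this place, or whether a cyclohexyl, a pyridine ring or a plain propyl chain on the same carbon would hold the number of compound 1. They also leave open what happens when the remaining benzyl group of compound 3 gives way as well, as with a second methyl on the amide-type nitrogen.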